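The source may hold more compounds than are shown below. What is called first, only, known or untested is meant among the compounds shown, and "the series" means these compounds.

Three compounds have been measured in an ADME assay on microsomes from liver (Rattus norvegicus) for metabolic stability; on this read-out lower numbers stand for slow clearance and higher numbers for fast clearance:

Compound 1 `CC(C)COc1ncc(-c2cc(F)c(-c3nnc(S(=O)(=O)CC4CC4)[nH]3)cc2F)cc1Cl` gives 58 uL/min.
Compound 2 `O=S(=O)(CC1CC1)c1nnc(-c2cc(F)c(-c3cnc(Oc4ccc(F)cc4F)c(Cl)c3)cc2F)[nH]1` gives 22 uL/min.
Compound 3 `CC(C)COc1ncc(-c2cc(F)c(-c3nnc(S(=O)(=O)NC4CC4)[nH]3)cc2F)cc1Cl` gives 54 uL/min.

Compound 2 stands lowest of the three, with its nearest neighbour compound 3 some way above it and compound 1 a little further still. Among the measured compounds shown here, only one measured step touches the oxygen on the aromatic ring: a 2.6-fold lower number from compound 1 to compound 2 (0.42 log units; beyond the scatter), a modest drop when a ring group replaced the isobutyl chain. The other step, a 1.1-fold lower number from compound 1 to compound 3 (0.03 log units; within the scatter), sits elsewhere and stayed within the scatter.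

Compound 4 `Cc1ccc(Cl)c(Oc2ncc(-c3cc(F)c(-c4nnc(S(=O)(=O)CC5CC5)[nH]4)cc3F)cc2Cl)c1` differs from compound 2 in 2-chloro-5-methylphenyl in place of 2,4-difluorophenyl on an oxygen on an aromatic ring. For the measured compounds named here, this is a swap of one ring group for another at the same oxygen, and no measured step shows such a ring-for-ring exchange, so the change cannot be read off directly. Because a 2.6-fold lower number from compound 1 to compound 2 (0.42 log units; beyond the scatter) was itself modest and both groups here are aromatic rings of the same size, compound 4 is expected to show a step of a 1.3-fold higher number from compound 2 to compound 4 (0.10 log units; within the scatter), most likely within the scatter. Compound 4 is estimated at 28 uL/min, ranging from 14 uL/min to 56 uL/min.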

Compound 4, intrinsic clearance in a liver preparation (reported as CLH), per the amount of preparation that the assay uses: 52 uL/min
Compound 4: middle estimate off by 1.9-fold (0.27 log units), on the low side, within the range that was stated.
By their numbers in this assay, from the lowest: compound 2; then compounds 4, 3 and 1 (each within the scatter of the next).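

At this oxygen on an aromatic ring, the identity of the ring matters in this assay: a 2.4-fold higher number from compound 2 to compound 4 (0.37 log units; beyond the scatter), even though the two groups have the same number of heavy atoms and each holds one six-membered aromatic ring of carbon only. A ring on this oxygen does not bring a lower number by itself: a 1.1-fold lower number from compound 1 to compound 4 (0.05 log units; within the scatter), which leaves the 2-chloro-5-methylphenyl and isobutyl compounds within the scatter of each other. Nothing available here accounts for the gap between the two rings.

The swap exchanges two fluorines for a chlorine and a methyl in a single move, so the compounds shown cannot tell which of these substituents matters. On these data alone, how a plain phenyl group on the same oxygen would read also remains open.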